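Fluoro in place of methyl on the aryl ether core

This account rests on a few compounds, and the source may have more. Where it says the series, first, only, none or still open, it means among the compounds named here.

Measured compounds:
- compound 1 `Cc1ccccc1OCC1=NCCO1`: 40%
- compound 2 `Cc1cc(OCC2=NCCO2)ccc1Cl`: 50%
- compound 3 `Fc1ccc(OCC2=NCCO2)cc1`: 25%

Of the compounds shown here, three built on the same aryl ether core have been tested in a toxicity assay on the whole organism with Rattus norvegicus as the target, at a dose of 100 mg/kg by the oral route; on this read-out lower numbers stand for a weaker effect and higher numbers for a stronger effect at the one dose given. Compound 1 stands second highest of the three numbers. Its nearest neighbour is compound 2, whose number is higher by an amount within the usual scatter, so nothing can be said about the order of these two. Compound 3 lies furthest away with a number lower than compound 1 by an amount beyond the scatter.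

Compound 4 `Fc1ccccc1OCC1=NCCO1` has not yet been tested. It differs from compound 1 by fluoro in place of methyl on an aromatic carbon. Among the measured compounds shown here, no step between measured compounds exchanges these two groups at the same position, so the data give no direct measure of what this change does in this assay. Because compound 3, which also carries fluoro on the ring, gives 25%, a small downward move is expected for compound 4, though one within the scatter. The expected step is a number 5 percentage points lower from compound 1 to compound 4 (within the scatter). Compound 4 is estimated at 35%, in a range from 15% to 55%.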

Compound 4, a percentage reported as activity, at one dose (the size of the read-out at that dose, not a potency): 40%
Compound 4: the middle estimate sits 5 percentage points below what was measured; low and high end bracket the measured number.
By their numbers in this assay, from the lowest: compound 3; then compounds 1, 4 and 2 (each within the scatter of the next).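

Fluoro in place of methyl on an aromatic carbon, ortho to a group of 7 heavy atoms, gives in this assay no change at the digits printed from compound 1 to compound 4 (within the scatter). This is the first pair among the compounds shown that differ in this one place, and it gives the exchange a direct reading that the earlier compounds could not provide: at this position and this single dose, the read-out does not separate the two groups. No measurement at hand bears on why they read alike.

The compounds shown leave open whether a larger or different group at this position, such as a methoxy group, an amine or a longer alkyl chain, would move the number beyond the scatter. They also leave open whether the same exchange of methyl for fluoro would read alike on another carbon of the ring.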